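Lipophilicity notes on a thienopyrimidinone amine series

A few compounds are considered here, and "the series" means these few. Any claim that something is new, unique, unknown or untested is made for them only; others in the source may bear on it.

Measured so far:
compound 1, `Cc1csc2cc([C@H](C)Nc3ncnc(N)c3C#N)c(-c3cccc(CC4CCN(C(C)C)CC4)c3)c(=O)n12`, 1.1
compound 2, `Cc1csc2cc([C@H](C)Nc3ncnc(N)c3C#N)c(-c3cccc(CN4CCC(CN(C)Cc5ccccn5)CC4)c3)c(=O)n12`, 2

Among the compounds with values here, in a physicochemical assay for lipophilicity (on this read-out lower numbers stand for lower lipophilicity and higher numbers for higher lipophilicity), compound 2 gives 2, the higher of the two numbers so far; compound 1 sits lower by a gap that lies beyond the scatter of this assay. Within the data shown here, no step between the two measured compounds is available, since they differ in more than one place, so only their two values are known.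

Compound 3, `Cc1csc2cc([C@H](C)Nc3ncnc(N)c3C#N)c(-c3cccc(CN4CCC(N(C)C)CC4)c3)c(=O)n12`, is the next compound to be measured in this assay. Relative to compound 2 the change is dimethylamino in place of (methyl((pyridin-2-yl)methyl)amino)methyl on a saturated ring carbon. The group that leaves carries one six-membered aromatic ring with 1 hetero atom and 10 heavy atoms; the group that enters has 3 heavy atoms and no ring.

Because compound 2 gives 2 and the change removes most of the heavy atoms of its side chain, a drop of moderate size is expected, a number 0.80 log units lower from compound 2 to compound 3 (beyond the scatter). Compound 3 is estimated at 1.2 in this assay, in a range of 0.6 to 1.8.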

Compound 3, distribution coefficient: 0.5
Estimate against measurement, compound 3: 0.70 log units above; measured number outside the range, below it.
By their numbers in this assay, from the lowest: compound 3; then compound 1; then compound 2.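

These notes compare steps in this assay. Dimethylamino in place of (methyl((pyridin-2-yl)methyl)amino)methyl on a saturated ring carbon gives a number 1.50 log units lower from compound 2 to compound 3 (beyond the scatter), the first one-place step at this position, and it shows that the read-out responds strongly to the group carried there. 4-(dimethylamino)piperidin-1-yl in place of 1-isopropylpiperidin-4-yl on a saturated chain carbon bound to an aromatic carbon gives a number 0.60 log units lower from compound 1 to compound 3 (beyond the scatter), a smaller step that leaves compound 3 with the lowest number of the three and shows that this side chain, too, can move the read-out beyond the scatter. No independent measurement accounts for the size of either step.

The compounds shown leave open how the larger step divides between the loss of the pyridine ring and the shortening of the chain, which a benzyl group or a plain dimethylaminomethyl group on the same saturated ring carbon would help to separate. They also leave open where a hydroxyl group or a carboxylic acid at that carbon would fall relative to compound 3 on this read-out.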